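Aryl ring exchange at one place of the shared core

The source may report more compounds than this note shows. Statements on the series, on what has been measured and on what is new or still open speak of the compounds shown alone.

Compound 2 `Cc1nn(-c2nc(-c3ccc(Cl)c(Cl)c3)c(SC(C)C)s2)c(C(=O)O)c1-c1cccc(Cl)c1` is, in a functional assay on BJAB cells (Homo sapiens) for antiproliferative activity, with a stated time of 4 days (on this read-out lower numbers stand for an effect already at smaller amounts and higher numbers for an effect only at larger amounts of compound), the compound with the highest number of the two measured, giving 13600 nM. Going by the values given here, its only measured neighbour is compound 1 `Cc1cc(Cl)cc(-c2c(C)nn(-c3nc(-c4ccc(Cl)c(Cl)c4)c(SC(C)C)s3)c2C(=O)O)c1`, which in this assay gives 663 nM; the step of a 21-fold higher number from compound 1 to compound 2 (1.31 log units; beyond the scatter) is large and shows that the ring carried at this place of the shared core is a spot where a small edit moved the number far. Compound 3 `Cc1nn(-c2nc(-c3ccc(Cl)c(Cl)c3)c(SC(C)C)s2)c(C(=O)O)c1-c1ccccc1[N+](=O)[O-]` continues at the same place: 2-nitrophenyl in place of 3-chlorophenyl on an aromatic carbon. Among the compounds with values here, no measured step covers this exchange, since the one step seen concerns a methyl leaving that ring rather than the whole ring being replaced. The size seen in a 21-fold higher number from compound 1 to compound 2 (1.31 log units; beyond the scatter) therefore only says that a step of similar size in either direction in this assay would not be surprising, and no direction can be claimed from the two numbers at hand. For compound 3 the number in this assay is estimated at 10000 nM, with a range of 1500 nM to 60000 nM, which means an expected step of a 1.4-fold lower number from compound 2 to compound 3 (0.13 log units; within the scatter) set near the starting point for lack of a guiding step.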

Compound 3, half-maximal effective concentration: 4700 nM
Beside the measured number, compound 3's estimate is 2.1-fold (0.33 log units) above it; the range from low to high includes it.
By their numbers in this assay, from the lowest: compound 1; then compound 3; then compound 2.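

In this assay, going by these compounds alone, the exchange of 3-chlorophenyl for 2-nitrophenyl gives a 2.9-fold lower number from compound 2 to compound 3 (0.46 log units; beyond the scatter) and so supplies the first reading of a whole-ring exchange at this place of the shared core; the earlier step concerned only a methyl on that ring. Set against the ring of compound 1, 3-chloro-5-methylphenyl, the same 2-nitrophenyl ring gives a 7.1-fold higher number from compound 1 to compound 3 (0.85 log units; beyond the scatter), which leaves compound 1 with the lowest number of the three and shows that 2-nitrophenyl recovers only part of the large gap opened by the loss of the methyl. This place therefore responds to the exchange of the ring as well as to the edit of a single methyl, although this ring exchange moves the number less far than that edit did. No measurement at hand bears on why the number moved in either step.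

The step from 3-chlorophenyl to 2-nitrophenyl changes both the group on the ring and where it stands, so the two contributions remain unseparated. A 3-nitrophenyl or a 2-chlorophenyl ring at this place would divide them, and a 2-aminophenyl ring would show whether the nitro group itself can be replaced.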